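The source may report more compounds than this note shows. Statements on the series, on what has been measured and on what is new or still open speak of the compounds shown alone.

Measured so far:
- compound 1, `COc1cc(C2=NN(C(C)=O)C(c3c(Cl)cccc3Cl)O2)cc(OC)c1OC`: -2.2%
- compound 2, `COc1cc(C2=NN(C(C)=O)C(c3cc(OC)c(OC)c(OC)c3)O2)cc(OC)c1OC`: 0.1%
- compound 3, `COc1cc(C(=O)N/N=C/c2ccccc2F)cc(OC)c1OC`: 81.8%

All three were tested in a functional assay on PC-3 cells (Homo sapiens) for antiproliferative activity, read by MTT assay, tested at 5 uM; a lower number here means a weaker effect, a higher number a stronger effect of the compound at the concentration tested. Compound 1 gives the lowest of the three numbers, and the number of compound 2 lies within the usual scatter of it, so the two cannot be told apart. Compound 3, which is built on a different framework from the shared core of compounds 1 and 2, gives a number far above that of compound 1, beyond the scatter.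

Compound 4, `COc1cc(C2=NN(C(C)=O)C(c3ccc(F)c(F)c3)O2)cc(OC)c1OC`, has not been measured. It differs from compound 1 in one place: 3,4-difluorophenyl in place of 2,6-dichlorophenyl on a saturated ring carbon. For the measured compounds named here, compounds 1 and 2 carry different aryl groups on that same saturated ring carbon and both sit near zero in this assay, which suggests the aryl group there has not moved the number so far. Going by the values given here, no step of this kind has been measured, so the step from compound 1 to compound 4 is expected to be small, in either direction or none beyond the scatter, as a number 4.2 percentage points higher from compound 1 to compound 4 (within the scatter). Compound 4 is therefore estimated at 2%, with a range from -10% to 18%.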

Compound 4, a percentage reported as inhibition, at one concentration (the size of the read-out at that concentration, not a potency): 46.9%
Compound 4: middle estimate off by 44.9 percentage points, on the low side; the measured number lies above the stated range.
By their numbers in this assay, from the lowest: compounds 1 and 2 (each within the scatter of the next); then compound 4; then compound 3.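

In this assay, putting 3,4-difluorophenyl in place of 2,6-dichlorophenyl on the saturated ring carbon gives a number 49.1 percentage points higher from compound 1 to compound 4 (beyond the scatter) and lifts the shared core out of the near-zero range. Compounds 1 and 2 alone made this aryl group look unimportant, but compound 4 shows that the number can depend strongly on which aryl group sits at this carbon. Nothing in the data given explains why this change has such a large effect.

The swap changes both the halogen and where it sits on the phenyl ring, and the compounds shown do not separate the two. As far as these compounds go, whether 3,4-dichlorophenyl or 2,6-difluorophenyl would stay close to compound 1 or approach compound 4 remains open, as does the outcome with an amine or a carboxylic acid on that ring.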